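Methoxy to fluoro on the amide ring: tolerability in cells

The source may report more compounds than this note shows. Statements on the series, on what has been measured and on what is new or still open speak of the compounds shown alone.

Compound 1 `COc1ccc(C(=O)Nc2ccc(CCS(=O)(=O)/C=C/c3ccc(O)c(O)c3)cc2)cc1`: in an ADME assay on TZM cells (Homo sapiens) for cytotoxicity, read by CCK-8 assay, with a stated time of 2 days (a lower number here means that less compound is tolerated, a higher number that more compound is tolerated), compound 1 gives > 1000000 nM, which is a limit of the assay and not a number.
Compound 2 `O=C(Nc1ccc(CCS(=O)(=O)/C=C/c2ccc(O)c(O)c2)cc1)c1ccc(F)cc1`: in this assay compound 2 gives > 1000000 nM, again a limit of the assay.
Compound 3 `COc1ccc(C(=O)Nc2ccc(CC[S+]([O-])/C=C/c3ccc(O)c(O)c3)cc2)cc1`: in this assay compound 3 has "not determined" (no result reported).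

Compounds 1 and 2 share a core and differ in one place: fluoro in place of methoxy on an aromatic carbon. The step that the two limits leave unreadable from compound 1 to compound 2 cannot be sized, since both values sit at the same boundary, (the limit of > 1000000 nM in this assay, at which 2 of the 3 values shown sit).

Compound 3 carries a different core; the difference between the two cores of compound 1 and compound 3 is not broken down here. Compound 4 `O=C(Nc1ccc(CC[S+]([O-])/C=C/c2ccc(O)c(O)c2)cc1)c1ccc(F)cc1` has not yet been measured in this assay. It stands to compound 3 exactly as compound 2 stands to compound 1: fluoro in place of methoxy on an aromatic carbon, and the surroundings of the changed position are described in the same words for both pairs, so this is the same change made a second time.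

For compound 3 no number exists to anchor a step, so the expectation for compound 4 rests on compounds 1 and 2 alone: the same change there left both compounds at the limit, (the limit of > 1000000 nM in this assay, at which 2 of the 3 values shown sit), and compound 4 is expected to behave alike. Compound 4 is therefore estimated at 2000000 nM in this assay, between 500000 nM and 10000000 nM, most likely reported only as a limit.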

Compound 4, half-maximal cytotoxic concentration: 127000 nM
Compound 4: middle estimate off by 16-fold (1.20 log units), on the high side; the measured number lies below the stated range.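

In this assay, going by these compounds alone, compound 4 gives 127000 nM, but compound 3 has no number to set beside it, so no step from compound 3 to compound 4 can be read. The compounds shown leave open how far putting fluoro in place of methoxy shifts the tolerated concentration on the core that compound 3 and compound 4 share.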